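Trimming Fluorines on the Aryl Ring of a Melanocortin Ligand

This account rests on a few compounds, and the source may have more. Where it says the series, first, only, none or still open, it means among the compounds named here.

Measured so far:
compound 1 `CC(C)[C@H](NC(=O)CCN(C)C)c1cccc(F)c1N1CCN(C(=O)[C@@H]2CN(C(C)C)C[C@H]2c2cc(F)c(F)c(F)c2)CC1` – 250 nM
compound 2 `Cc1ccc(N2CCN(C(=O)[C@@H]3CNC[C@H]3c3ccc(Cl)cc3)CC2)c([C@@H](NC(=O)CCN(C)C)C(C)C)c1` – 7.2 nM

In an assay on HEK293 cells for displacement of a labelled ligand from Melanocortin receptor 4 (Homo sapiens) (on this read-out lower numbers stand for stronger inhibition and higher numbers for weaker inhibition), compound 1 gives 250 nM, the higher of the two numbers; compound 2, built on a different core, gives 7.2 nM, a much lower number that lies beyond the scatter. Compound 3 `CC(C)[C@H](NC(=O)CCN(C)C)c1cccc(F)c1N1CCN(C(=O)[C@@H]2CN(C(C)C)C[C@H]2c2cccc(F)c2)CC1` keeps the core of compound 1 and carries 3-fluorophenyl in place of 3,4,5-trifluorophenyl on a saturated ring carbon. Among the measured compounds shown here, no measured pair shows the effect of removing fluorines here, so the step from compound 1 is expected to be small, likely within the scatter, a 1.3-fold lower number from compound 1 to compound 3 (0.10 log units; within the scatter). Compound 3 is therefore estimated at 200 nM, within 60 nM to 700 nM.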

Compound 3, inhibition constant: 560 nM
Estimate against measurement, compound 3: 2.8-fold (0.45 log units) below; measured number inside the range.
By their numbers in this assay, from the lowest: compound 2; then compound 1; then compound 3.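

In this assay, the step from the trifluorinated ring to the single fluorine gives a 2.2-fold higher number from compound 1 to compound 3 (0.35 log units; beyond the scatter) and so shows, in this one pair, that losing fluorines from this ring on the saturated ring carbon raises the number modestly rather than leaving it unchanged. Nothing available explains this shift. 

Still open, going by these compounds, is how a plain phenyl ring, with no fluorine at all, would read at this position. A ring bearing a methoxy group is equally uncharted, so whether the trend continues or reverses cannot yet be said.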